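Substitution on the aniline nitrogen and cytotoxicity in MT4 cells

A few compounds are considered here, and "the series" means these few. Any claim that something is new, unique, unknown or untested is made for them only; others in the source may bear on it.

Of the compounds shown here, two of a shared core have been measured so far. Compound 1 `Cc1ccc(-c2c(C)c(-c3ccc(C)c(C)c3)c(C(OC(C)(C)C)C(=O)O)c(C)c2NS(=O)(=O)C2CC2)cc1C` carries a cyclopropylsulfonyl group on a nitrogen on an aromatic ring, and in an ADME assay on MT4 cells (Homo sapiens) for cytotoxicity, read by MTT assay, with a stated time of 4 days (a higher number here means that more compound is tolerated, a lower number that less compound is tolerated), compound 1 gives 11000 nM. Compound 2 `Cc1ccc(-c2c(C)c(-c3ccc(C)c(C)c3)c(C(OC(C)(C)C)C(=O)O)c(C)c2N)cc1C` carries a hydrogen on that nitrogen instead, and in this assay compound 2 gives 12000 nM. The step of a 1.1-fold higher number from compound 1 to compound 2 (0.04 log units; within the scatter) shows that removing the cyclopropylsulfonyl group did not move the number beyond the scatter. On the two numbers available, compound 2 stands highest, with compound 1 nearest and within the scatter of it.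

Compound 3 `CCNC(=O)Nc1c(C)c(C(OC(C)(C)C)C(=O)O)c(-c2ccc(C)c(C)c2)c(C)c1-c1ccc(C)c(C)c1` differs from compound 2 by ethylcarbamoyl in place of hydrogen on a nitrogen on an aromatic ring. Among the measured compounds shown here, the only measured step that bears on this change is the one between compound 1 and compound 2, which swapped a substituent on the same nitrogen for hydrogen and stayed within the scatter. On that basis the step of no change at the digits printed from compound 2 to compound 3 (within the scatter) is expected to be no larger than the scatter, in no particular direction. For compound 3 the expected value in this assay is therefore 12000 nM, with a range from 6000 nM to 25000 nM.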

Compound 3, half-maximal cytotoxic concentration: 15000 nM
Beside the measured number, compound 3's estimate is 1.3-fold (0.10 log units) below it; measured number inside the range.
By their numbers in this assay, from the lowest: compounds 1, 2 and 3 (each within the scatter of the next).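

On this nitrogen on an aromatic ring, ethylcarbamoyl in place of hydrogen gives in this assay a 1.3-fold higher number from compound 2 to compound 3 (0.10 log units; within the scatter) and so adds a second substituent, one joined through a carbonyl rather than a sulfonyl group, that leaves the number within the scatter of the unsubstituted compound. The direct exchange of the two substituents, with a 1.4-fold higher number from compound 1 to compound 3 (0.13 log units; within the scatter) as its result, shows what the earlier pair could not: the two substituents also stay within the scatter of each other, so hydrogen, cyclopropylsulfonyl and ethylcarbamoyl on this nitrogen cannot be told apart by these numbers. No accompanying measurement offers an explanation for this flat picture on the shared core.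

Going by these compounds, it remains open whether a longer chain in place of the ethyl part of ethylcarbamoyl, or an amine or a carboxylic acid carried on such a chain, would move the number beyond the scatter. On these data alone, it also remains open whether the same indifference to the substituent on this nitrogen would hold on a core with other groups in place of the tert-butoxy group or the dimethylphenyl rings.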